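From 4-methylphenyl to 3-methoxyphenyl on a shared core

A few compounds are considered here, and "the series" means these few. Any claim that something is new, unique, unknown or untested is made for them only; others in the source may bear on it.

Measured so far in a physicochemical assay for solubility; a lower number here means a less soluble compound, a higher number a more soluble compound:
Compound 1 `CNC(=O)c1cc(C(=O)NCCCC2CNCCO2)cn(Cc2ccccc2)c1=O`: >= 194 ug/mL
Compound 2 `CNC(=O)c1cc(C(=O)NC2CC2)cn(Cc2ccc(C)cc2)c1=O`: 24 ug/mL
Compound 3 `CNC(=O)c1cc(C(=O)NC2CCC2)cn(Cc2ccccn2)c1=O`: >= 103 ug/mL

Among the compounds with values here, compound 2 holds the only actual number in this small set, at 24 ug/mL. The reading for compound 1 is a limit, >= 194 ug/mL. The reading for compound 3 is also a limit, >= 103 ug/mL.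

Compound 4 `CNC(=O)c1cc(C(=O)NC2CC2)cn(Cc2cccc(OC)c2)c1=O` departs from compound 2 in one place, with 3-methoxyphenyl in place of 4-methylphenyl on a saturated chain carbon bound to an aromatic nitrogen. Within the data shown here, no measured pair here shows a change of this kind, so compound 2 at 24 ug/mL is the only anchor. The expected step is a 1.5-fold higher number from compound 2 to compound 4 (0.16 log units; within the scatter), a small rise that stays within the usual scatter of this assay. For compound 4 the estimated value is 35 ug/mL, with an expected range of 15 ug/mL to 80 ug/mL.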

Compound 4, solubility: 79 ug/mL
For compound 4 the middle estimate is 2.3-fold (0.35 log units) below the measured one; the measured number falls inside the stated range.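

Within the data shown here, this is the first single change in the set that can be read in this assay, and it shows that this place, a saturated chain carbon bound to an aromatic nitrogen, can move the reading: 3-methoxyphenyl in place of 4-methylphenyl gives a 3.3-fold higher number from compound 2 to compound 4 (0.52 log units; beyond the scatter). No measurement shown gives a reason for this rise.

The compounds shown leave open whether the rise follows the methoxy group or its place on the ring, which 3-methylphenyl or 4-methoxyphenyl could separate. They also leave open how an amine on the ring would read at this place.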